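A few compounds are considered here, and "the series" means these few. Any claim that something is new, unique, unknown or untested is made for them only; others in the source may bear on it.

Among the compounds with values here, compound 1 (`O=C1O/C(=C\Cn2cnc3cc[nH]c3c2=O)C(OCc2ccccc2)=C1OCc1ccccc1`) is the only compound in this small set with a measured number: in a functional assay on CCRF-CEM cells (Homo sapiens) for antiproliferative activity, read by MTT assay, with a stated time of 72 h (on this read-out lower numbers stand for stronger inhibition and higher numbers for weaker inhibition), compound 1 gives 16000 nM. Compound 2 (`O=C1O/C(=C\Cn2cnc3ccnc(Cl)c32)C(OCc2ccccc2)=C1OCc1ccccc1`) provides no such reference point, because in this assay compound 2 is recorded as "not determined" (no result reported), so it has no place on the scale. Compound 3 (`O=C1O/C(=C\Cn2cnc3ncc(Br)c-3c2)C(OCc2ccccc2)=C1OCc1ccccc1`) comes from compound 2 by exchanging a single group: a group of 10 heavy atoms (6 carbon, 3 nitrogen, 1 bromine; one five-membered aromatic ring with 1 hetero atom, one six-membered aromatic ring with 2 hetero atoms) in place of a group of 10 heavy atoms (6 carbon, 3 nitrogen, 1 chlorine; one five-membered aromatic ring with 2 hetero atoms, one six-membered aromatic ring with 1 hetero atom), on a saturated chain carbon bound to a double-bonded chain carbon. The exchange takes place on a saturated chain carbon bound to a double-bonded chain carbon, and the entering group carries bromine where the leaving group carried chlorine. Within the data shown here, no measured step shows how much such an exchange matters, so the expectation rests on compound 1 at 16000 nM, with no shift beyond the usual scatter in either direction. Compound 3 is expected at about 14000 nM, with an estimated range from 3500 nM to 55000 nM.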

Compound 3, half-maximal inhibitory concentration: 12000 nM
The estimate for compound 3 lay 1.2-fold (0.07 log units) above the measured number; low and high end bracket the measured number.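

In this assay the exchange on a saturated chain carbon bound to a double-bonded chain carbon gives a 1.3-fold lower number from compound 1 to compound 3 (0.12 log units; within the scatter) and so separates compound 1 and compound 3 by no more than ordinary repeat variation. At this place, a group carrying bromine and a group carrying oxygen, both of 10 heavy atoms, therefore give results that cannot be told apart, while the step from compound 2 to compound 3 cannot be read: compound 2 has no number. No available data link this result to any property of either group.

On these data alone, whether an amine, a carboxylic acid or a longer chain at this place would move the number beyond the scatter remains open. So does the result of exchanging bromine for chlorine on an otherwise identical group, with both compounds measured.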